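The compounds below may be only part of what the source reports. "The series", "measured", "known", "first", "only" and "open" are said of these compounds alone.

The set rests on a shared core carrying a variable side chain, all tested in a functional assay on CHO-K1 cells for antagonist activity at adenosine receptor A1 (Homo sapiens), read by a beta-galactosidase reporter and cAMP accumulation, with stated times of 15 min and 6 h; on this read-out lower numbers stand for stronger inhibition and higher numbers for weaker inhibition. Compound 1, `Cc1ccc(-c2nc(N)c3cc(CCc4ccccc4)sc3n2)o1`, gives 2780 nM. Compound 3, `Cc1ccc(-c2nc(N)c3cc(C(C)c4ccccc4)sc3n2)o1`, gives 439 nM. For compound 2, `Cc1ccc(-c2nc(N)c3cc(Cc4ccccc4F)sc3n2)o1`, this assay reports only a limit, < 16 nM (the limit of < 16 nM in this assay, at which 1 of the 3 values shown sits). Among the two numbers that are not limits, compound 3 stands lowest, and the step of a 6.3-fold lower number from compound 1 to compound 3 (0.80 log units; beyond the scatter) lies beyond the scatter. The step of an at least 170-fold lower number from compound 1 to compound 2 (2.23 log units; beyond the scatter) and the step of an at least 27-fold higher number from compound 2 to compound 3 (1.43 log units; beyond the scatter) each involve that limit and so give only a bound on their size.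

Compound 4, `CC(c1ccccc1)c1cc2c(N)nc(-c3cccc(C#N)c3)nc2s1`, has not yet been measured in this assay. It differs from compound 3 by 3-cyanophenyl in place of 5-methylfuran-2-yl on an aromatic carbon. Among the measured compounds shown here, all three measured steps change the side chain on the saturated chain carbon; none of them alters the group at the position changed here, so no measured step bears directly on this change. The expected step of a 1.1-fold lower number from compound 3 to compound 4 (0.04 log units; within the scatter) is therefore one that stays within the scatter. The estimate for compound 4 in this assay is 400 nM, ranging from 100 nM to 1600 nM.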

Compound 4, inhibition constant: 1770 nM
Estimate against measurement, compound 4: 4.4-fold (0.65 log units) below; measured number above the stated range.
By their numbers in this assay, from the lowest: compound 3; then compounds 4 and 1 (each within the scatter of the next). At a limit, below all of these: compound 2.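

Among the compounds shown here, this is the first evidence on the group on the aromatic carbon between two ring nitrogen atoms, since every earlier step changed only the side chain. With 1-phenylethyl held fixed, this assay shows that this position is not indifferent to its substituent: 3-cyanophenyl in place of 5-methylfuran-2-yl gives a 4.0-fold higher number from compound 3 to compound 4 (0.61 log units; beyond the scatter), a modest weakening that rests on this single pair. Nothing measured among these compounds accounts for the step.

The compounds shown do not separate the change of ring from the added nitrile, and a plain phenyl or an unsubstituted furan-2-yl at this position would bear on that. Going by these compounds, it also stays open whether the step would carry over to the side chains of compound 1 or compound 2.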